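Trimethoxyphenyl replacing dimethoxyphenyl on the saturated ring carbon

A few compounds are considered here, and "the series" means these few. Any claim that something is new, unique, unknown or untested is made for them only; others in the source may bear on it.

Compound 1 `Clc1ccc(C2=NN(c3ccc(-c4ccccc4)nn3)C(c3ccc(Cl)cc3)C2)cc1` and compound 2 `Fc1ccc(C2CC(c3ccc(Cl)cc3)=NN2c2ccc(-c3ccccc3)nn2)cc1` carry halophenyl groups on the saturated ring carbon of the shared core. In a functional assay on HepG2 cells (Homo sapiens) for antiproliferative activity, read by MTT assay, with a stated time of 24 h (on this read-out lower numbers stand for stronger inhibition and higher numbers for weaker inhibition), compound 1 gives 10000 nM and compound 2 gives 10000 nM; the step of no change at the digits printed from compound 1 to compound 2 (within the scatter). Compound 3 `COc1ccc(C2CC(c3ccc(Cl)cc3)=NN2c2ccc(-c3ccccc3)nn2)c(OC)c1` carries a 2,4-dimethoxyphenyl group in that place. In this assay compound 3 reaches only a limit, > 100000 nM. This is the limit of > 100000 nM in this assay, at which 1 of the 3 values shown sits. The steps of an at least 10-fold higher number from compound 1 to compound 3 (1.00 log units; beyond the scatter) and an at least 10-fold higher number from compound 2 to compound 3 (1.00 log units; beyond the scatter) both run the same way.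

Compound 4 `COc1cc(C2CC(c3ccc(Cl)cc3)=NN2c2ccc(-c3ccccc3)nn2)cc(OC)c1OC` differs from compound 3 by 3,4,5-trimethoxyphenyl in place of 2,4-dimethoxyphenyl on a saturated ring carbon. For the measured compounds named here, no measured step compares one methoxyphenyl pattern with another; the only steps that bear on the change, from compound 1 and from compound 2 to compound 3, show that a methoxyphenyl group on this carbon gave a higher number, at least modestly. The expected step of a number no higher from compound 3 to compound 4 (the limit leaves the size open) is therefore none beyond the scatter, with the result likely again at the limit. Compound 4 is estimated at 100000 nM, with a range of 20000 nM to 300000 nM.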

Compound 4, half-maximal inhibitory concentration: > 100000 nM
Compound 4 gave a limit, no number; the forecaster's own chance of this, stated with the estimate: 60%; the middle value lies on the limit itself.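

In this assay the 3,4,5-trimethoxyphenyl group on this saturated ring carbon gives the same direction of change as the 2,4-dimethoxyphenyl group: an at least 10-fold higher number from compound 1 to compound 4 (1.00 log units; beyond the scatter), and an at least 10-fold higher number from compound 2 to compound 4 (1.00 log units; beyond the scatter). The higher number against the 4-chlorophenyl and 4-fluorophenyl compounds is therefore not confined to one methoxyphenyl pattern, and it holds across both compounds with methoxy groups shown here. The step between compound 3 and compound 4 cannot be read, so the two methoxy patterns cannot be ranked, and this series now reaches the assay limit twice: the limit of > 100000 nM in this assay, at which 2 of the 4 values shown sit.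

Still open, as far as these compounds go, is whether a 4-aminophenyl or 4-carboxyphenyl group on this carbon would stay with the halophenyl compounds or go to the limit. Also open, from the compounds shown here alone, is whether a change to the 4-chlorophenyl group on the other ring carbon would alter the number.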